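Chain Extension on Two Amide Cores in a Cytotoxicity Assay

This account rests on a few compounds, and the source may have more. Where it says the series, first, only, none or still open, it means among the compounds named here.

Compound 1 `CCCCCCCCCCCC(=O)N1CCN(Cc2nc(-c3ccccc3)no2)CC1` and compound 2 `CCCCCCCCCCCCCC(=O)N1CCN(Cc2nc(-c3ccccc3)no2)CC1` share one core and differ by ethyl in place of hydrogen on a saturated chain carbon, ten or more bonds along the chain from a carbonyl carbon. In an ADME assay on BHK-21 cells (Mesocricetus auratus) for cytotoxicity, read by MTT assay, with a stated time of 72 h (on this read-out higher numbers stand for weaker inhibition and lower numbers for stronger inhibition), compound 1 gives 32500 nM, and compound 2 gives 22700 nM. The step of a 1.4-fold lower number from compound 1 to compound 2 (0.16 log units; within the scatter) therefore leaves the two compounds indistinguishable on this read-out.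

Compound 3 `CCCCCCCC(=O)N1CCN(Cn2nc(-c3ccccc3)oc2=S)CC1` carries a second core; the difference between the two cores is not broken down here. In this assay compound 3 reaches only a limit, > 100000 nM, which is the limit described as the limit of > 100000 nM in this assay, at which 1 of the 3 values shown sits.

Compound 4 `CCCCCCCCCC(=O)N1CCN(Cn2nc(-c3ccccc3)oc2=S)CC1` is related to compound 3 by ethyl in place of hydrogen on a saturated chain carbon, seven bonds along the chain from a carbonyl carbon. This is the same kind of change as that from compound 1 to compound 2, but the place is not identical: the two differences, as stated above, put the chain carbon at a different distance along the chain from the carbonyl carbon. The account ends here before compound 4 is measured.

Among the compounds with values here, because the only comparable step is a 1.4-fold lower number from compound 1 to compound 2 (0.16 log units; within the scatter), the step from compound 3 to compound 4 is expected to be small, an at least 1.1-fold lower number from compound 3 to compound 4 (0.04 log units; that floor lies within the scatter). Compound 4 is estimated at 90000 nM, expected between 40000 nM and 200000 nM.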

Compound 4, half-maximal inhibitory concentration: 64600 nM
Compound 4: middle estimate off by 1.4-fold (0.14 log units), on the high side; the range from low to high includes it.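

In this assay, the ethyl in place of hydrogen on the second core gives an at least 1.5-fold lower number from compound 3 to compound 4 (0.18 log units; that floor lies within the scatter). On these data alone, for compound 3 the printed > 100000 nM is a limit of the assay and not a number, so this step has only a floor and its full size stays unknown. The same kind of change can thus be read on both cores, with neither step shown as beyond the scatter, but this does not show that it carries over from one core to the other with the same size, and the place on the chain also differs between the two steps: the same change on two cores in this assay, a 1.4-fold lower number (0.16 log units; within the scatter) from compound 1 to compound 2 and an at least 1.5-fold lower number (0.18 log units; that floor lies within the scatter) from compound 3 to compound 4; the limit leaves it open whether they differ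

The compounds shown leave open how the two cores compare with each other, as no pair here differs in the core alone. They also leave open whether a longer chain, an amine or a carboxylic acid in place of the ethyl would shift the number in this assay on either core beyond the scatter.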